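The compounds below may be only part of what the source reports. "The series", "measured", "known", "first", "only" and "open" are said of these compounds alone.

Going by the values given here, compound 1, with the structure `CCc1nc(N)nc(N)c1C#CC(C)c1ccc(-c2ccncc2)cc1OC`, is the only member of this small set with a numerical result. In an ADME assay on MCF10 cells (Homo sapiens) for cytotoxicity (on this read-out higher numbers stand for weaker inhibition and lower numbers for stronger inhibition), compound 1 gives 216000 nM, a weak effect. Compound 2, `CCc1nc(N)nc(N)c1C#CC(C)c1ccc(-c2ccc(C)cc2)cc1OC`, belongs to the same series, but in this assay compound 2 is recorded as "not determined" (no result reported), so compound 1 stands alone on the numbers, with nothing to rank it against.

Compound 3, `CCc1nc(N)nc(N)c1C#CC(C)c1ccc(-c2ccc(C(=O)OC)cc2)cc1OC`, shares the core of compound 1 and differs in one place: 4-(methoxycarbonyl)phenyl in place of pyridin-4-yl on an aromatic carbon. Among the compounds with values here, no step between two measured compounds exists to guide the reading of this change, so the expectation must rest on compound 1 alone.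

Given that compound 1 gives 216000 nM in this assay, the step from a 1.4-fold lower number from compound 1 to compound 3 (0.13 log units; within the scatter) is expected to stay within the usual scatter, with no clear direction. Compound 3 is therefore estimated at 160000 nM in this assay, within a range from 50000 nM to 500000 nM.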

Compound 3, half-maximal inhibitory concentration: 96000 nM
Beside the measured number, compound 3's estimate is 1.7-fold (0.22 log units) above it, and the stated range covers the measured number.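

In this assay the position on the aromatic carbon, para to a large group, responds to this exchange: 4-(methoxycarbonyl)phenyl in place of pyridin-4-yl gives a 2.3-fold lower number from compound 1 to compound 3 (0.35 log units; beyond the scatter), a modest step but the first one that can be read in this series. Going by these compounds alone, the single step carries two changes at once, since the ring hetero atom leaves and a methoxycarbonyl group enters on a ring of carbon only, so it cannot assign the shift to either. Nothing given here accounts for the step.

As far as these compounds go, whether the lower number follows the carbon-only ring or the ester therefore remains open. From the compounds shown here alone, a plain phenyl ring, or a carboxylic acid or an amide in place of the methyl ester at the same place, would be needed to separate the two, and how these would read is unknown.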